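This account rests on a few compounds, and the source may have more. Where it says the series, first, only, none or still open, it means among the compounds named here.

The measured compounds:
compound 1, `Cc1cn(C2CCN(Cc3cccc(Oc4cc(Cl)cc(Cl)c4)c3)CC2)c(=O)[nH]c1=O`: 6730 nM in an ADME assay on MRC5 cells (Homo sapiens) for cytotoxicity, read by fluorescence and resazurin assay, with a stated time of 3 days; a higher number here means a weaker inhibitor, a lower number a stronger inhibitor
compound 2, `Cc1cn(C2CCN(Cc3cccc(Oc4cccc(Cl)c4)n3)CC2)c(=O)[nH]c1=O`: > 64000 nM in this assay

These two compounds share a core and differ in their outer aromatic ring and in the ring that carries it, so they offer no single-change comparison. In this assay, for the measured compounds named here, compound 1 gives 6730 nM, the only actual number among the two results. Compound 2 gives > 64000 nM, which is a limit of the assay rather than a number. Going by the values given here, compound 1 thus stands as the one compound with a measured value, while the other result sits at the limit of > 64000 nM in this assay, at which 1 of the 2 values shown sits.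

The unmeasured compound 3, `Cc1cn(C2CCN(Cc3cccc(Oc4cccc(OC(F)(F)F)c4)c3)CC2)c(=O)[nH]c1=O`, is built from compound 1 by one change: 3-(trifluoromethoxy)phenyl in place of 3,5-dichlorophenyl on an oxygen on an aromatic ring. For this change the step of a 1.5-fold higher number from compound 1 to compound 3 (0.17 log units; within the scatter) is expected to be small, most likely within the scatter of repeated measurements, with no clear direction. Compound 3 is therefore estimated at 10000 nM in this assay, with a range from 3000 nM to 40000 nM.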

Compound 3, half-maximal inhibitory concentration: 5260 nM
For compound 3 the middle estimate is 1.9-fold (0.28 log units) above the measured one; the range from low to high includes it.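

For the compounds shown here, putting 3-(trifluoromethoxy)phenyl in place of 3,5-dichlorophenyl on an oxygen on an aromatic ring gives a 1.3-fold lower number from compound 1 to compound 3 (0.11 log units; within the scatter) in this assay, and this is the first comparison here in which only one part of the molecule differs. The read-out therefore does not separate these two outer rings, even though the entering group has more heavy atoms and brings a hydrogen-bond acceptor that the leaving group lacks. Nothing available explains why the two groups give results this close, so the comparison records the outcome without a cause.

Going by these compounds alone, compound 2 carries a limit of the assay rather than a number, and it differs from the other two compounds in more than one place, so no step to it can be read. On these data alone, it also remains open whether the read-out would stay in this range with a different kind of group on the outer ring, such as an amine or a carboxylic acid, since both groups compared here are halogen-bearing phenyl rings.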